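A Second Trifluoromethyl Added to an Unreadable Limit

The compounds below may be only part of what the source reports. "The series", "measured", "known", "first", "only" and "open" are said of these compounds alone.

Compound 3 `COc1cc(-c2nn(-c3cccc(NC(=O)Nc4cccc(C(F)(F)F)c4)c3)cc2-c2ccncc2)ccc1Cl` stands at a limit in a functional assay on SN12C cells (Homo sapiens) for inhibition, read by sulforhodamine B assay, with a stated time of 48 h; on this read-out lower numbers stand for higher toxicity in this test and higher numbers for lower toxicity in this test: compound 3 gives > 50000 nM, which is a limit of the assay and not a number. Compound 1 `COc1cc(-c2nn(-c3cccc(NC(=O)c4cccc(C(F)(F)F)c4)c3)cc2-c2ccncc2)ccc1Cl` gives > 50000 nM, also a limit. The step that the two limits leave unreadable from compound 1 to compound 3 therefore cannot be read, because the limit of > 50000 nM in this assay, at which 3 of the 3 values shown sit, holds both of its ends. Compound 2 `O=C(Nc1cccc(-n2cc(-c3ccncc3)c(-c3ccc(Cl)c(O)c3)n2)c1)Nc1cc(C(F)(F)F)cc(C(F)(F)F)c1` gives > 50000 nM, again a limit. Compound 4 `COc1cc(-c2nn(-c3cccc(NC(=O)Nc4cc(C(F)(F)F)cc(C(F)(F)F)c4)c3)cc2-c2ccncc2)ccc1Cl` differs from compound 3 by trifluoromethyl in place of hydrogen on an aromatic carbon. Among the measured compounds shown here, no measured step of readable size bears on this change; every value shown sits at the same limit, and compound 2 differs from compound 4 only elsewhere in the shared core. No step beyond the scatter is expected in this assay, so a step that the limit leaves unreadable from compound 3 to compound 4 is expected to be flat. Compound 4 is therefore estimated at 80000 nM, between 30000 nM and 300000 nM, and most likely reported again only as a limit.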

Compound 4, concentration lethal to 50% of the cells: > 50000 nM
Compound 4 gave a limit, no number; the forecaster's own chance of this, stated with the estimate: 85%; the middle value lies beyond the limit too.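

Neither the step from compound 3 to compound 4 nor the step from compound 2 to compound 4 can be read: the limit of > 50000 nM in this assay, at which 4 of the 4 values shown sit.

The compounds shown leave open what size, if any, each of these changes has in this assay.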